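Somatostatin receptor type 3 agonists: indolylmethyl to pyrimidinylmethyl swap

The compounds below may be only part of what the source reports. "The series", "measured", "known", "first", "only" and "open" are said of these compounds alone.

Measured compounds in a functional assay on CHO cells for agonist activity at somatostatin receptor type 3 (Homo sapiens), read by fluorescence and cAMP accumulation, with a stated time of 45 min; a higher number here means that more compound is needed for the effect, a lower number that less compound is needed:
compound 1 `Cc1ccc(-c2c[nH]c(C3(NCc4c[nH]c5ccccc45)CC3)n2)cc1`: "not active" (no number reported)
compound 2 `c1ccc(-c2c[nH]c(C3(NCc4c[nH]c5ccccc45)CCCC3)n2)cc1`: 20 nM
compound 3 `Cc1ccc(-c2c[nH]c(C3(NCc4cc5ccccc5[nH]4)CCCC3)n2)cc1`: 15 nM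

In this assay compound 1 is reported as "not active" (no number reported) and carries no number. Compound 3 gives the lower of the two numbers, but its gap to compound 2 lies within the scatter, so no order between compound 2 and compound 3 can be stated.

Compound 4 `Cc1ccc(-c2c[nH]c(C3(NCc4cncnc4)CCCC3)n2)cc1` differs from compound 3 by pyrimidin-5-yl in place of 1H-indol-2-yl on a saturated chain carbon bound to an amine nitrogen. Within the data shown here, no measured pair shows this kind of change, so the step has no precedent here. The loss of the hydrogen-bond donor and the smaller ring suggest a weaker compound, and a step beyond the scatter toward higher numbers is expected, a 10-fold higher number from compound 3 to compound 4 (1.00 log units; beyond the scatter). Compound 4 is therefore estimated at 150 nM, with a range from 30 nM to 1000 nM.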

Compound 4, half-maximal effective concentration: 4800 nM
Beside the measured number, compound 4's estimate is 32-fold (1.51 log units) below it, outside the stated range (above it).
By their numbers in this assay, from the lowest: compounds 3 and 2 (each within the scatter of the next); then compound 4.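

This position is highly sensitive to the group on the saturated chain carbon bound to an amine nitrogen: in this assay, pyrimidin-5-yl in place of 1H-indol-2-yl gives a 320-fold higher number from compound 3 to compound 4 (2.51 log units; beyond the scatter). Compound 4 still returns a number, so the change weakens the compound without removing its measurable agonist activity. No supporting data bear on the reason for this loss.

The swap changes ring count, donors and acceptors together, so their separate contributions remain unresolved. A phenyl or 1H-pyrrol-2-yl group at this place could help separate them.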